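Dithiol hydroxamate and anilide series: growth inhibition notes

The source may report more compounds than this note shows. Statements on the series, on what has been measured and on what is new or still open speak of the compounds shown alone.

Measured compounds:
- compound 1, `O=C(CCCCC(S)CCS)NO`: 41.5%
- compound 2, `O=C(CCCCC(S)CCS)Nc1ccccc1`: 8.62%
- compound 3, `O=C(CCCCC(S)CCS)Nc1ccc(OC(F)(F)F)cc1`: 15%

In a functional assay on KB cells (Homo sapiens) for inhibition, read by MTT assay, with a stated time of 24 h, tested at 10 ug/mL (on this read-out higher numbers stand for more inhibition of growth at the one concentration tested and lower numbers for less inhibition of growth), compound 2 gives the lowest of the three numbers. Compound 3 lies closest to it, the step of a number 6.4 percentage points higher from compound 2 to compound 3 (within the scatter) being within the scatter; compound 1 lies furthest, the step of a number 32.9 percentage points lower from compound 1 to compound 2 (beyond the scatter) being beyond it.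

Compound 4, `Cc1cccc(NC(=O)CCCCC(S)CCS)c1`, is the next anilide of the shared core. Relative to compound 2 the change is methyl in place of hydrogen on an aromatic carbon.

Going by the values given here, the step that bears on this change is the one from compound 2 to compound 3, where another substituent entered an aromatic carbon of the same ring: a number 6.4 percentage points higher from compound 2 to compound 3 (within the scatter), within the scatter. The step from compound 1 to compound 2 concerns the amide-type nitrogen, not the ring, and so says little here. On this basis no step beyond the scatter is expected for compound 4 in this assay, and a number 1.4 percentage points higher from compound 2 to compound 4 (within the scatter) is the expected step. Compound 4 is therefore estimated at 10%, with a range from 0% to 25%.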

Compound 4, percent growth inhibition at one concentration: 7.23%
For compound 4 the middle estimate is 2.8 percentage points above the measured one, within the range that was stated.
By their numbers in this assay, from the lowest: compounds 4, 2 and 3 (each within the scatter of the next); then compound 1.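

Methyl in place of hydrogen on this aromatic carbon, meta to a large group, gives a number 1.4 percentage points lower from compound 2 to compound 4 (within the scatter) in this assay and so adds one carbon to the anilide ring with no step that can be told from the scatter. With a number 6.4 percentage points higher from compound 2 to compound 3 (within the scatter) as the other ring step, two ring substituents, trifluoromethoxy and methyl, now each stay within the scatter of compound 2, and no ring change shown gives a step beyond it. No measurement shown bears on why the methyl leaves the number where it stands.

Open, on these data alone, is whether an amine, a carboxylic acid or a longer alkyl chain on this same ring carbon would give a step beyond the scatter. Also open, as far as these compounds go, is how methyl behaves on the other carbons of the ring, and whether compound 4 and compound 2 would stay together at other concentrations.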